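Replacing 3-methoxyphenyl with pyridin-2-yl on the amide

This account rests on a few compounds, and the source may have more. Where it says the series, first, only, none or still open, it means among the compounds named here.

Measured compounds:
compound 1 `CCCCc1ccc(NC(=O)C2CCN(C/C=C/c3ccccc3)CC2)cc1`: 4320 nM
compound 2 `COc1cccc(NC(=O)C2CCN(C/C=C/c3ccccc3)CC2)c1`: 78600 nM
compound 3 `O=C(Nc1cccc(C(F)(F)F)c1)C1CCN(C/C=C/c2ccccc2)CC1`: 11400 nM

All three compounds were tested in a functional assay on HepG2 cells (Homo sapiens) for inhibition, read by MTT assay, with a stated time of 72 h; on this read-out higher numbers stand for weaker inhibition and lower numbers for stronger inhibition. Compound 2 stands highest of the three at 78600 nM, which makes it the weakest inhibitor among them. Compound 3 gives 11400 nM and compound 1 gives 4320 nM, and both numbers lie clearly lower.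

The next compound to consider is compound 4 `O=C(Nc1ccccn1)C1CCN(C/C=C/c2ccccc2)CC1`. It keeps the shared core and differs from compound 2 in one place: pyridin-2-yl in place of 3-methoxyphenyl on an amide-type nitrogen. In words, pyridin-2-yl sits in place of 3-methoxyphenyl on an amide-type nitrogen.

Among the measured compounds shown here, no measured compound carries pyridin-2-yl, so the data hold no direct measure of this swap. The closest evidence is a single step, a 6.9-fold lower number from compound 2 to compound 3 (0.84 log units; beyond the scatter), in which trifluoromethyl replaces methoxy on an aromatic carbon. That modest step is a different change, so it offers only a weak guide. It does show that losing the methoxy went with a lower number in this one case.

A modest move towards a lower number in this assay is therefore expected, though a result within the scatter remains possible. The expected change is a 2.0-fold lower number from compound 2 to compound 4 (0.29 log units; within the scatter). For compound 4 the estimated value is 40000 nM, with an expected range from 13000 nM to 110000 nM.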

Compound 4, half-maximal inhibitory concentration: 51100 nM
Beside the measured number, compound 4's estimate is 1.3-fold (0.11 log units) below it; the measured number falls inside the stated range.
By their numbers in this assay, from the lowest: compound 1; then compound 3; then compounds 4 and 2 (each within the scatter of the next).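

In this assay, replacing the whole 3-methoxyphenyl ring on the amide-type nitrogen with pyridin-2-yl gives a 1.5-fold lower number from compound 2 to compound 4 (0.19 log units; within the scatter), so the number does not clearly move even though a ring of carbon only gives way to a smaller ring holding a nitrogen atom. Among the compounds shown here, the earlier compounds changed only a group carried on the aromatic ring, so this is the first view of a change to the ring itself, and in this one pair the change leaves no readable difference. Nothing available here explains why these two rings give numbers so close together.

The compounds shown leave open how other rings on the same amide-type nitrogen would read, such as pyridin-3-yl or pyridin-4-yl, or an aromatic ring carrying an amine or a carboxylic acid. They also leave open whether adding trifluoromethyl to pyridin-2-yl would bring a shift of the kind seen in a 6.9-fold lower number from compound 2 to compound 3 (0.84 log units; beyond the scatter), which would show whether that earlier change carries over to a ring containing nitrogen.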